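Swapping Fluoro for Hydroxy on an Aromatic Carbon

This account rests on a few compounds, and the source may have more. Where it says the series, first, only, none or still open, it means among the compounds named here.

In a functional assay (microsomes, liver) with Rattus norvegicus as the target (on this read-out lower numbers stand for stronger inhibition and higher numbers for weaker inhibition), compound 1 `Cc1c(C)c2c(c(C)c1N)CC(C)(CSc1ccccc1)O2` gives 270 nM and compound 2 `Cc1c(C)c2c(c(C)c1N)CC(C)(CSc1ccc(F)cc1)O2` gives 220 nM. Among the measured compounds shown here, these are the only two numbers available so far, and they lie within the usual scatter of each other, so compound 2 stands level with compound 1. The next structure, compound 3 `Cc1c(C)c2c(c(C)c1N)CC(C)(CSc1ccc(O)cc1)O2`, keeps the shared core but carries hydroxy in place of fluoro on an aromatic carbon, para to a large group: hydroxy in place of fluoro on an aromatic carbon.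

For the measured compounds named here, only one measured step bears on this change. It is a 1.2-fold lower number from compound 1 to compound 2 (0.09 log units; within the scatter), which put fluoro in place of hydrogen on an aromatic carbon. Going by the values given here, that step offers only limited guidance, since no measured compound carries hydroxy and no measured step shows what this group does. With nothing pointing either way, no shift beyond the scatter is expected in this assay, and no direction can be favoured. The expected step is a 1.0-fold higher number from compound 2 to compound 3 (0.02 log units; within the scatter). For compound 3 the estimated value is 230 nM, with an expected range from 90 nM to 600 nM.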

Compound 3, half-maximal inhibitory concentration: 220 nM
Compound 3: middle estimate off by 1.0-fold (0.02 log units), on the high side; the measured number falls inside the stated range.
By their numbers in this assay, from the lowest: compounds 2, 3 and 1 (each within the scatter of the next).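

Hydroxy brings a hydrogen-bond donor and a hydrogen-bond acceptor to this aromatic carbon, para to a large group, where fluoro has neither, and in this assay this swap gives no change at the digits printed from compound 2 to compound 3 (within the scatter). Measured against the compound with plain hydrogen at the same place, the result is a 1.2-fold lower number from compound 1 to compound 3 (0.09 log units; within the scatter), so with the earlier fluoro step in view, hydrogen, fluoro and hydroxy all stand level at this position, each within the scatter of the others. Nothing measured here offers an explanation for this sameness.

Still open, as far as these compounds go, is whether the position stays this undemanding for groups with more atoms or a different character, such as an amine, a carboxylic acid, a methoxy group or a longer chain on the same carbon. Also open is whether moving hydroxy to another carbon of the six-membered aromatic ring would leave the number level, and whether the three compounds stay level outside this assay, the only read-out shown.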